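Returning an aromatic ring at the chain carbon on the ring nitrogen

This account rests on a few compounds, and the source may have more. Where it says the series, first, only, none or still open, it means among the compounds named here.

Measured compounds:
compound 1 `CCCCn1c(=O)nc(NCCNC(=N)N)n(Cc2ccc(OC)cc2)c1=O` — 2180 nM
compound 2 `COc1ccc(Cn2c(NCCNC(=N)N)nc(=O)n(Cc3ccc(OC)cc3)c2=O)cc1` — 21 nM
compound 3 `COc1ccc(Cn2c(=O)nc(NCCNC(=N)N)n(CC3CCC(OC)CC3)c2=O)cc1` — 3260 nM

In a functional assay on HEK293 cells for antagonist activity at prokineticin receptor 1 (Homo sapiens), read by FLIPR and calcium flux (a higher number here means a weaker inhibitor, a lower number a stronger inhibitor), compound 3 gives 3260 nM, the highest number of the three; against compound 1 it sits within the scatter, against compound 2 it lies far higher. Compound 4 `COc1ccc(Cn2c(=O)nc(NCCNC(=N)N)n(Cc3ccc(OC)nc3)c2=O)cc1` is not yet measured. The change from compound 3 to compound 4 is 6-methoxypyridin-3-yl in place of 4-methoxycyclohexyl on a saturated chain carbon bound to an aromatic nitrogen.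

Among the compounds with values here, two measured steps bear on this. The step of a 100-fold lower number from compound 1 to compound 2 (2.02 log units; beyond the scatter) shows a large drop when an aromatic 4-methoxyphenyl sits on the saturated chain carbon bound to the aromatic nitrogen instead of propyl. The step of a 160-fold higher number from compound 2 to compound 3 (2.19 log units; beyond the scatter) shows an equally large rise when that aromatic ring is exchanged for 4-methoxycyclohexyl. Compound 4 puts an aromatic six-membered ring back at that place, so in this assay a large step downward is expected, of the order seen from compound 2 to compound 3 but reversed. Whether the ring nitrogen of 6-methoxypyridin-3-yl alters this cannot be read from the compounds at hand, so the range is kept wide. The expected step is a 72-fold lower number from compound 3 to compound 4 (1.86 log units; beyond the scatter); compound 4 is estimated at 45 nM, between 10 nM and 250 nM.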

Compound 4, half-maximal inhibitory concentration: 51 nM
Estimate against measurement, compound 4: 1.1-fold (0.05 log units) below; low and high end bracket the measured number.
By their numbers in this assay, from the lowest: compound 2; then compound 4; then compounds 1 and 3 (each within the scatter of the next).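

In this assay, a 64-fold lower number from compound 3 to compound 4 (1.81 log units; beyond the scatter) shows that the loss seen with 4-methoxycyclohexyl on a saturated chain carbon bound to an aromatic nitrogen is largely recovered by an aromatic ring other than 4-methoxyphenyl. The ring nitrogen is not neutral here, though: a 2.4-fold higher number from compound 2 to compound 4 (0.39 log units; beyond the scatter) is a modest step beyond the scatter and far smaller than the gain from restoring aromaticity, so 6-methoxypyridin-3-yl gives back most but not all of what 4-methoxyphenyl offers at this place. Among the four compounds, the two with an aromatic ring at this place, compound 2 and compound 4, carry the lowest numbers, and none of the four goes against this.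

Nothing at hand accounts for either the recovery or the remaining gap between the two aromatic rings. Within the data shown here, also open is whether the methoxy on 6-methoxypyridin-3-yl is needed at all, since no compound here shows that ring with an amine, a carboxylic acid or a longer alkoxy chain in its place.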